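A few compounds are considered here, and "the series" means these few. Any claim that something is new, unique, unknown or untested is made for them only; others in the source may bear on it.

Compound 1 `CCOC(=O)c1cnc(N2CCN(Cc3ccc(C#N)cc3)CC2)nc1Oc1c(C)cc(-c2ccc(C#N)cc2)cc1C`: > 125000 nM
Compound 2 `CCOC(=O)c1cnc(N2CCN(Cc3cccc(Br)c3)CC2)nc1Oc1c(C)cc(-c2ccc(C#N)cc2)cc1C`: > 125000 nM

Of the compounds shown here, two built on one shared core have been tested in an ADME assay on MT4 cells (Homo sapiens) for cytotoxicity, read by MTT assay, with a stated time of 4 days; on this read-out lower numbers stand for higher toxicity in this test and higher numbers for lower toxicity in this test. For compound 1 the reading is a limit of the assay rather than a number, > 125000 nM. For compound 2 the reading is likewise a limit, > 125000 nM. Compound 2 therefore stands at the limit of > 125000 nM in this assay, at which 2 of the 2 values shown sit, and the change from compound 1, a step that the two limits leave unreadable from compound 1 to compound 2, cannot be given a size, since neither end is a number.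

Compound 3 `CCOC(=O)c1cnc(N2CCN(Cc3cc(F)cc(F)c3)CC2)nc1Oc1c(C)cc(-c2ccc(C#N)cc2)cc1C` has not yet been measured. It differs from compound 2 in one place: 3,5-difluorophenyl in place of 3-bromophenyl on a saturated chain carbon bound to an amine nitrogen in a ring. Going by the values given here, the only measured step touching this same place is a step that the two limits leave unreadable from compound 1 to compound 2, and it yields no readable size, so it offers no direction. The expectation instead rests on both measured compounds sitting at the limit of > 125000 nM in this assay, at which 2 of the 2 values shown sit. Compound 3 is expected to show no step beyond the scatter, a step that the limit leaves unreadable from compound 2 to compound 3, and to sit once more at the limit. The estimated value of compound 3 in this assay is 150000 nM, with a range from 60000 nM to 400000 nM.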

Compound 3, half-maximal cytotoxic concentration: > 125000 nM
Compound 3 ended at the assay's limit; the forecaster's own chance of this, stated with the estimate: 85%; the middle value lies beyond the limit too.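

No size can be given for the change to compound 3 from either compound 1 or compound 2, since all three readings in this assay are limits of the assay rather than numbers: the limit of > 125000 nM in this assay, at which 3 of the 3 values shown sit.

The compounds shown leave open how far each lies beyond that limit, and whether any group at this place would give a readable number.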